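The source may hold more compounds than are shown below. What is called first, only, known or untested is meant among the compounds shown, and "the series" means these compounds.

Compound 1 `Cc1ccccc1-c1nn(Cc2ccc(F)cc2)cc1CNCCN1CCN(C)CC1` in an ADME assay on Huh-7 cells (Homo sapiens) for cytotoxicity (a higher number here means that more compound is tolerated, a lower number that less compound is tolerated), is reported only as a limit, > 20000 nM.
Compound 2 `CN1CCN(CCNCc2cn(-c3ccc(F)cc3F)nc2-c2ccc(OC(F)(F)F)cc2)CC1` in this assay gives 18000 nM.
Compound 3 `Cc1ccccc1-c1nn(-c2ccc(F)c(F)c2)cc1CNCCN1CCN(C)CC1` in this assay is likewise reported only as a limit, > 20000 nM.

Compound 3 therefore stands at the top of what this assay resolves, and one further value in the set is also a limit; see (the limit of > 20000 nM in this assay, at which 2 of the 3 values shown sit). Among the compounds with values here, the one change among the measured compounds that differs in a single place, a step that the two limits leave unreadable from compound 1 to compound 3, cannot be read in size, since both ends are limits. Within the data shown here, compound 2 is the only member with a number, and it lies close to the limit of the others.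

Compound 4 `CCOC(=O)Cn1cc(CNCCN2CCN(C)CC2)c(-c2ccccc2C)n1` is the next member. It differs from compound 3 in one place: (ethoxycarbonyl)methyl in place of 3,4-difluorophenyl on an aromatic nitrogen. Among the measured compounds shown here, no measured step bears directly on this change, and the only step of the set is unreadable. With every value shown at or close to the limit, the expectation for compound 4 is a step of no size beyond the scatter, a step that the limit leaves unreadable from compound 3 to compound 4. Compound 4 is accordingly estimated at 22000 nM, in the range 11000 nM to 50000 nM, and most likely to be returned again as a limit.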

Compound 4, half-maximal cytotoxic concentration: > 20000 nM
Compound 4: a limit, no number (the forecaster's own chance of this, stated with the estimate: 70%); the middle value is on the limit's open side.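

Compound 4 is a limit in this assay, as are compound 1 and compound 3, so neither step to compound 4 can be read: the limit of > 20000 nM in this assay, at which 3 of the 4 values shown sit. Still open, from the compounds shown here alone, is whether the group on the aromatic nitrogen changes the tolerated concentration at all.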